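A few compounds are considered here, and "the series" means these few. Any claim that something is new, unique, unknown or untested is made for them only; others in the source may bear on it.

Working notes on the series.

Three compounds of the shared core have numbers in an assay on HEK293 cells for displacement of a labelled ligand from 5-hydroxytryptamine receptor 6 (Homo sapiens), read by radioligand binding, with a stated time of 1 h; on this read-out higher numbers stand for weaker inhibition and lower numbers for stronger inhibition. Compound 1 `CN1CCN(c2nc(N)nc(COc3cccc(Cl)c3)n2)CC1` gives 148 nM in this assay. Compound 3 `Cc1ccccc1OCc1nc(N)nc(N2CCN(C)CC2)n1` gives 87 nM, and compound 2 `Cc1ccc(C(C)C)c(OCc2nc(N)nc(N3CCN(C)CC3)n2)c1` gives 11 nM. Among the three, compound 3 stands second highest: its nearest neighbour is compound 1, and the change from compound 1 to compound 3 amounted to a 1.7-fold lower number from compound 1 to compound 3 (0.23 log units; within the scatter). Its furthest neighbour is compound 2, whose number is markedly lower than that of compound 3, well beyond the scatter.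

Compound 4 `CN1CCN(c2nc(N)nc(COc3ccc(Cl)cc3Cl)n2)CC1` is not yet measured. It differs from compound 3 by 2,4-dichlorophenyl in place of 2-methylphenyl on an oxygen on a saturated carbon. Going by the values given here, the only measured step at this position is the exchange from compound 1 to compound 3, which gave a 1.7-fold lower number from compound 1 to compound 3 (0.23 log units; within the scatter), a swap of one aryl for another that stayed within the scatter. Among the compounds with values here, compound 2 shows that a more heavily substituted aryl at the same oxygen can sit well below compound 3, but no single-point step leads to it. A 2,4-dichlorophenyl is therefore expected to move the number little, if at all, beyond the scatter, with a slight lean towards a lower value.

For compound 4 the expected step from compound 3 is a 1.5-fold lower number from compound 3 to compound 4 (0.16 log units; within the scatter). Compound 4 is accordingly estimated at 60 nM in this assay, within a range of 20 nM to 200 nM.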

Compound 4, inhibition constant: 128 nM
Compound 4: the middle estimate sits 2.1-fold (0.33 log units) below what was measured; the measured number falls inside the stated range.
By their numbers in this assay, from the lowest: compound 2; then compounds 3, 4 and 1 (each within the scatter of the next).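

The aryl group on the oxygen now has three members that read alike in this assay: there is a 1.5-fold higher number from compound 3 to compound 4 (0.17 log units; within the scatter), and there is a 1.2-fold lower number from compound 1 to compound 4 (0.06 log units; within the scatter). Exchanging 2-methylphenyl or 3-chlorophenyl for 2,4-dichlorophenyl therefore leaves the number within the scatter at this position, whether the group entering replaces a methyl-bearing or a chlorine-bearing aryl, so a second substituent on the aryl does not by itself set the number; compound 2 goes against any broader reading of this, as its aryl also carries more than one substituent and it stands apart at 11 nM. No measurement is at hand that bears on why these three aryl groups read alike.

Still open, from the compounds shown here alone, is which feature of the aryl of compound 2 goes with its lower number, as the three other aryl groups give no lead on this. Also open, going by these compounds, is how the number responds when the aryl on the oxygen carries an amine or a carboxylic acid, or gives way to a saturated cyclohexyl ring or a longer chain.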